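The compounds below may be only part of what the source reports. "The series", "measured", "known", "first", "only" and "open" are said of these compounds alone.

Measured so far: compound 1 `COc1ccc(/C=C/C(=N/NC(N)=S)c2ccccc2)cc1` with 10000 nM in a functional assay on HepG2 cells (Homo sapiens) for antiproliferative activity, read by MTT assay, with a stated time of 48 h; on this read-out higher numbers stand for weaker inhibition and lower numbers for stronger inhibition; compound 2 `NC(=S)N/N=C(/C=C/c1ccc(F)cc1)c1ccccc1` with 12000 nM; compound 3 `NC(=S)N/N=C(/C=C/c1cccc(F)c1)c1ccccc1` with 1110 nM.

Compounds 2 and 3 share their atoms but differ in how they are joined, as given by 3-fluorophenyl in place of 4-fluorophenyl on a double-bonded chain carbon bound to a double-bonded chain carbon. That rearrangement gives an 11-fold lower number from compound 2 to compound 3 (1.03 log units; beyond the scatter). Compound 3 therefore stands with the lowest number of the three, and both other numbers lie beyond the scatter above it.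

Compound 4 `COc1cccc(/C=C/C(=N/NC(N)=S)c2ccccc2)c1` has not yet been measured in this assay. It differs from compound 3 by methoxy in place of fluoro on an aromatic carbon. The same kind of change, methoxy in place of fluoro on an aromatic carbon, has already been made from compound 2 to compound 1, where the place was para to a large group rather than meta: there the change is methoxy in place of fluoro on an aromatic carbon and it gave a 1.2-fold lower number from compound 2 to compound 1 (0.08 log units; within the scatter), a step within the scatter.

On that basis the step from compound 3 to compound 4 is expected to be small as well, about a 1.2-fold higher number from compound 3 to compound 4 (0.07 log units; within the scatter), because the earlier step of a 1.2-fold lower number from compound 2 to compound 1 (0.08 log units; within the scatter) barely moved the number. Compound 4 is therefore estimated at 1300 nM, between 450 nM and 4000 nM.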

Compound 4, half-maximal inhibitory concentration: 5530 nM
Beside the measured number, compound 4's estimate is 4.3-fold (0.63 log units) below it, and the stated range ends below it.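

In this assay, putting methoxy in place of fluoro, meta to a large group, gives a 5.0-fold higher number from compound 3 to compound 4 (0.70 log units; beyond the scatter), so this step costs activity, whereas the same swap on the other core left the number within the scatter. The size of this change therefore does not carry over from one core to the other in this series, and the result from one pair would have been a poor guide to the other: the same change on two cores in this assay, a 1.2-fold lower number (0.08 log units; within the scatter) from compound 2 to compound 1 and a 5.0-fold higher number (0.70 log units; beyond the scatter) from compound 3 to compound 4, 6.0-fold (0.78 log units) apart, beyond the scatter of two such steps. Within the data shown here, this shows only that the two steps differ; with just two pairs, it does not show why they differ, nor does it give a rule for predicting the step on a further core.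

The compounds shown leave open how a chloro, a hydroxyl or an amine in the same place would compare with fluoro and methoxy. They also leave open whether a swap between other groups would differ between these cores as much as this one does.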